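Ring closure of the amine side chain and topoisomerase inhibition

This account rests on a few compounds, and the source may have more. Where it says the series, first, only, none or still open, it means among the compounds named here.

Compound 1, `COc1c(N2CC[C@@H](CN)C2)c(F)cc2c(=O)c(C(=O)O)cn(Cc3ccc(-c4ccccc4)cc3)c12`, gives 26000 nM in an assay on isolated protein for inhibition of DNA topoisomerase 1 (Homo sapiens), with a stated time of 15 min; a lower number here means a stronger inhibitor, a higher number a weaker inhibitor. Compound 2, `CNCCCNc1c(F)cc2c(=O)c(C(=O)O)cn(Cc3ccc(-c4ccccc4)cc3)c2c1OC`, gives 101000 nM in this assay. Compound 3, `CNCCNc1c(F)cc2c(=O)c(C(=O)O)cn(Cc3ccc(-c4ccccc4)cc3)c2c1OC`, gives > 200000 nM in this assay, and this is a limit rather than a number.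

Among the measured compounds shown here, compound 3 thus stands at the edge of what this assay reports, at the limit of > 200000 nM in this assay, at which 1 of the 3 values shown sits, and it is the only one of the three values given that way. Compound 4, `CNC[C@@H]1CCN(c2c(F)cc3c(=O)c(C(=O)O)cn(Cc4ccc(-c5ccccc5)cc4)c3c2OC)C1`, differs from compound 3 in one place: 3-((methylamino)methyl)pyrrolidin-1-yl in place of (2-(methylamino)ethyl)amino on an aromatic carbon. For the measured compounds named here, two measured steps bear on this change. The step of an at least 7.6-fold higher number from compound 1 to compound 3 (0.88 log units; beyond the scatter) runs in the opposite direction to the one now taken, from the pyrrolidine of compound 1 to the open chain of compound 3, and the step of a 3.9-fold higher number from compound 1 to compound 2 (0.59 log units; beyond the scatter) points the same way. The step of an at least 1.9-fold higher number from compound 2 to compound 3 (0.29 log units; that floor lies within the scatter) says little, as its floor lies within the scatter. Going by the values given here, the ring entering compound 4 carries a (methylamino)methyl group rather than the aminomethyl of compound 1, and no measured pair separates those two groups on the ring. Compound 4 is therefore expected to return to a number near that of compound 1, a downward step of an at least 6.6-fold lower number from compound 3 to compound 4 (0.82 log units; beyond the scatter). The estimate for compound 4 is 30000 nM, with an expected range from 10000 nM to 100000 nM.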

Compound 4, half-maximal inhibitory concentration: 155000 nM
Estimate against measurement, compound 4: 5.2-fold (0.71 log units) below; the whole stated range lies below it.
By their numbers in this assay, from the lowest: compound 1; then compounds 2 and 4 (each within the scatter of the next). At a limit, above all of these: compound 3.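

Among the compounds shown here, the clearest new reading in this assay concerns the side-chain amine: methyl in place of hydrogen on that nitrogen is the only change, and it costs a step beyond the scatter (a 6.0-fold higher number from compound 1 to compound 4 (0.78 log units; beyond the scatter)). So the low number of compound 1 does not carry over to every pyrrolidine at this aromatic carbon, and the amine nitrogen matters as well as the ring. With the methyl in place, 3-((methylamino)methyl)pyrrolidin-1-yl and (3-(methylamino)propyl)amino cannot be told apart (a 1.5-fold higher number from compound 2 to compound 4 (0.19 log units; within the scatter)), and the remaining step (an at least 1.2-fold lower number from compound 3 to compound 4 (0.11 log units; that floor lies within the scatter)) has a floor within the scatter and starts from a value that is a limit and not a number: the limit of > 200000 nM in this assay, at which 1 of the 4 values shown sits.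

The compounds shown leave open whether the same exchange of hydrogen for methyl would count equally on an open chain, as with a terminal primary amine on the (3-aminopropyl)amino chain. They also leave open whether a dimethylamino group on the pyrrolidine would raise the number further, and what the opposite stereocentre would do to either ring.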